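Dropping one benzyl arm from compound 1

A few compounds are considered here, and "the series" means these few. Any claim that something is new, unique, unknown or untested is made for them only; others in the source may bear on it.

Compound 1 `Cc1ccc2cc(CN(Cc3ccc(F)cc3)Cc3ccc(C(C)C)cc3)c(=O)[nH]c2c1` carries two benzyl arms on an amine nitrogen attached to the shared core. In a toxicity assay on MDCK cells (Canis lupus familiaris) for cytotoxicity, read by crystal violet staining, with a stated time of 48 h (on this read-out higher numbers stand for lower toxicity in this test and lower numbers for higher toxicity in this test), compound 1 gives > 33000 nM, which is a limit of the assay rather than a number. Compound 2 `Cc1ccc2cc(CN(Cc3ccc(C(C)C)cc3)Cc3cccc(F)c3)c(=O)[nH]c2c1` differs from compound 1 only in where the fluorine sits on one arm. In this assay compound 2 gives > 33000 nM, again a limit and not a number. The step that the two limits leave unreadable from compound 1 to compound 2 therefore tells nothing about size; the two measured values share (the limit of > 33000 nM in this assay, at which 2 of the 2 values shown sit). Compound 3 `Cc1ccc2cc(CNCc3ccc(F)cc3)c(=O)[nH]c2c1` is the unmeasured compound. It differs from compound 1 by hydrogen in place of 4-isopropylbenzyl on an amine nitrogen. Within the data shown here, no measured step involves removing a whole arm of this kind, so the only guide is that compound 1 itself gave no number. Compound 3 is expected to stay at the same limit, with an estimated 40000 nM and a range from 20000 nM to 100000 nM. The step that the limit leaves unreadable from compound 1 to compound 3 is thus expected to be none beyond the scatter.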

Compound 3, half-maximal cytotoxic concentration: > 33000 nM
Compound 3 gave a limit, no number (the forecaster's own chance of this, stated with the estimate: 85%); the middle value is on the limit's open side.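

Compound 1 and compound 3 both give only a limit of the assay rather than a number, so no step between them can be read in this assay: the limit of > 33000 nM in this assay, at which 3 of the 3 values shown sit.

The compounds shown leave open whether losing the 4-isopropylbenzyl arm changes toxicity in these cells at all.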